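The source may hold more compounds than are shown below. What is called first, only, known or untested is meant among the compounds shown, and "the series" means these compounds.

Measured so far in an assay on isolated protein for inhibition of aldehyde dehydrogenase 1A1 (Homo sapiens); a higher number here means a weaker inhibitor, a lower number a stronger inhibitor:

compound 1 `CC(Sc1nc2nn(C3COC3)cc2c(=O)n1-c1ccccc1)c1ccccc1` gives 109 nM
compound 2 `CC(Oc1nc2c(cnn2C)c(=O)n1-c1ccccc1)c1ccccc1` gives 2400 nM
compound 3 `Cn1ncc2c(=O)n(-c3ccccc3)c(CNc3cccc(F)c3)nc21` gives 570 nM

Compound 2 stands at the highest number of the three. Its nearest neighbour is compound 3, whose number is lower by a gap that lies beyond the usual scatter, and compound 1 sits furthest away, with a much lower number. Among the compounds with values here, the three compounds differ in more than one place, so no single step between them can be isolated.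

The next compound, compound 4 `Cn1ncc2c(=O)n(-c3ccccc3)c(OCc3cccc(F)c3)nc21`, is reached from compound 2 by one change: 3-fluorobenzyl in place of 1-phenylethyl on an oxygen on an aromatic ring. The oxygen linkage of compound 2 is kept.

Within the data shown here, no step between measured compounds matches this change. Compound 3 carries the same 3-fluorobenzyl group on a different linking atom and gives a lower number than compound 2, so a moderate fall in the number is expected, though the unknown share of the linker in that gap keeps the expectation loose. The step of a 2.4-fold lower number from compound 2 to compound 4 (0.38 log units; beyond the scatter) is expected to run downward by a modest amount. Compound 4 is estimated at 1000 nM, with a range from 300 nM to 4000 nM.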

Compound 4, half-maximal inhibitory concentration: 775 nM
Beside the measured number, compound 4's estimate is 1.3-fold (0.11 log units) above it; the range from low to high includes it.
By their numbers in this assay, from the lowest: compound 1; then compounds 3 and 4 (each within the scatter of the next); then compound 2.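

In this assay, within the data shown here, 3-fluorobenzyl in place of 1-phenylethyl on an oxygen on an aromatic ring gives a 3.1-fold lower number from compound 2 to compound 4 (0.49 log units; beyond the scatter), the only step that isolates a single change and the first evidence that this position responds to its substituent. The response comes with the heavy-atom count unchanged and with one six-membered aromatic ring of carbon only and no hydrogen-bond donors or acceptors on either side, so those counts do not separate the two groups. Nothing available accounts for the fall in the number.

The step combines loss of the branching methyl with gain of the fluorine, and unsubstituted benzyl on the same oxygen would separate the two. On these data alone, how this position responds to a group without an aromatic ring, such as a short alkyl chain or a chain ending in an amine, remains open.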